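Hydroxy added to the hexylamide of compound 2

The source may report more compounds than this note shows. Statements on the series, on what has been measured and on what is new or still open speak of the compounds shown alone.

Among the compounds with values here, the two compounds measured so far share a cinnamoyl core. Compound 1 `O=C(O)/C=C/c1cc(O)c(O)c(O)c1` carries a free carboxylic acid. In a functional assay on WiDr cells (Homo sapiens) for cytotoxicity, read by sulforhodamine B assay, with a stated time of 48 h (a lower number here means a stronger inhibitor, a higher number a weaker inhibitor), compound 1 returns only a limit, > 200000 nM, not a number. Compound 2 `CCCCCCNC(=O)/C=C/c1ccc(O)c(O)c1` carries a hexylamide instead, and in this assay compound 2 gives 34600 nM. Compound 2 thus stands at the only actual number shown here; the one further value shown is a limit, (the limit of > 200000 nM in this assay, at which 1 of the 2 values shown sits).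

Compound 3 `CCCCCCNC(=O)/C=C/c1cc(O)c(O)c(O)c1` is the next case. It keeps the hexylamide of compound 2 and differs from it in one place: hydroxy in place of hydrogen on an aromatic carbon. Within the data shown here, no measured pair in this set shows what such a change does in this assay, so the size of the step cannot be read from the data. The expected step from compound 2 to compound 3 is a 1.2-fold higher number from compound 2 to compound 3 (0.06 log units; within the scatter), which is not expected to exceed the scatter by much in either direction. Compound 3 is therefore estimated at 40000 nM, in a range from 15000 nM to 120000 nM.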

Compound 3, half-maximal inhibitory concentration: 82400 nM
Compound 3: middle estimate off by 2.1-fold (0.31 log units), on the low side, and the stated range covers the measured number.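

Within the data shown here, the step of a 2.4-fold higher number from compound 2 to compound 3 (0.38 log units; beyond the scatter) is the first single change that can be read in this assay. It shows that, with the hexylamide held fixed, adding a hydroxy group on this aromatic carbon, ortho to a hydroxy group, does not leave the number unchanged but moves it modestly towards weaker inhibition. Compound 1, which carries a free carboxylic acid in place of the hexylamide, returns only a limit, > 200000 nM, and so offers no number against which this hydroxy can be judged a second time. Nothing shown here bears on why the added hydroxy moves the number in this direction.

Going by these compounds, whether a methoxy group or a fluorine atom at the same carbon would move the number in the same way remains open. Among these compounds, it is also open whether the step would hold with a longer chain or an ester in place of the hexylamide, since this single pair is the only reading of the change.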